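Swapping Methyl for Fluoro Across Two Cores

The compounds below may be only part of what the source reports. "The series", "measured", "known", "first", "only" and "open" are said of these compounds alone.

Compound 1 `C/C(=C\c1cc(-c2ccc(C)nc2)co1)C(N)=O` and compound 2 `C/C(=C\c1cc(-c2ccc(F)nc2)co1)C(N)=O` share one core, while compound 3 `C/C(=C\c1nc(-c2ccc(C)cc2)cs1)C(N)=O` and compound 4 `C/C(=C\c1nc(-c2ccc(F)cc2)cs1)C(N)=O` share another; the difference between the two cores is not broken down here. In a functional assay on A549 cells (Homo sapiens) for cytotoxicity, read by CCK-8 assay, with a stated time of 24 h (on this read-out higher numbers stand for weaker inhibition and lower numbers for stronger inhibition), compound 1 gives only a limit, > 50000 nM. Compound 2 likewise reaches only a limit, > 50000 nM. Compound 3 also stops at a limit, > 50000 nM. The step that the two limits leave unreadable from compound 1 to compound 2 comes from the change (fluoro in place of methyl on an aromatic carbon). The change fluoro in place of methyl on an aromatic carbon is the same kind of change, but it sits on a six-membered aromatic ring of carbon only rather than on a ring with one nitrogen, next to the ring nitrogen. Because (the limit of > 50000 nM in this assay, at which 3 of the 3 values shown sit), compound 4 is expected to stay at the limit as well, so that a step that the limit leaves unreadable from compound 3 to compound 4 is expected to be unreadable. Compound 4 is therefore estimated at 100000 nM in this assay.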

Compound 4, half-maximal inhibitory concentration: 13200 nM
Beside the measured number, compound 4's estimate is 7.6-fold (0.88 log units) above it; measured number below the stated range.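

In this assay, fluoro in place of methyl gives an at least 3.7-fold lower number from compound 3 to compound 4 (0.57 log units; beyond the scatter), so on the core of compound 3 the change lowers the number beyond the scatter. The same change on the core of compound 1 cannot be read, since compound 1 and compound 2 both stop at a limit: the limit of > 50000 nM in this assay, at which 3 of the 4 values shown sit. The series therefore shows the effect on one core only, and it does not show whether the change carries over to the other core, either in direction or in size.

Going by these compounds, it remains open whether another group on that aromatic carbon, such as chloro, an amine or a carboxylic acid, would lower the number further on the core of compound 3. On these data alone, it also remains open whether any such group would bring the core of compound 1 off its limit.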